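The source may report more compounds than this note shows. Statements on the series, on what has been measured and on what is new or still open speak of the compounds shown alone.

Among the measured compounds shown here, compound 2 `C/C(=C\C(=O)Nc1ccccc1OCCCC(=O)O)c1ccc2c(ccn2Cc2ccc(F)cc2)c1` gives the highest of the two numbers so far, 97 nM in an assay on Prostate gland for inhibition of steroid 5-alpha-reductase (Rattus norvegicus); on this read-out higher numbers stand for weaker inhibition and lower numbers for stronger inhibition; its nearest neighbour, compound 1 `CCCC(C)n1ccc2cc(/C(C)=C/C(=O)Nc3ccccc3OCCCC(=O)O)ccc21`, gives 7.8 nM. Compound 3 `CCCCCC(c1ccccc1)n1ccc2cc(/C(C)=C/C(=O)Nc3ccccc3OCCCC(=O)O)ccc21` carries 1-phenylhexyl in place of 4-fluorobenzyl on an aromatic nitrogen. For the measured compounds named here, one measured step bears on this position: a 12-fold higher number from compound 1 to compound 2 (1.09 log units; beyond the scatter). A branched alkyl on this nitrogen thus went with the lower number, and compound 3 keeps a branched chain while retaining an aromatic ring, so a lower number is expected for compound 3, about an 8.1-fold lower number from compound 2 to compound 3 (0.91 log units; beyond the scatter). The estimate for compound 3 is 12 nM, within 3 nM to 45 nM.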

Compound 3, half-maximal inhibitory concentration: 25 nM
Compound 3: the middle estimate sits 2.1-fold (0.32 log units) below what was measured; low and high end bracket the measured number.
By their numbers in this assay, from the lowest: compound 1; then compound 3; then compound 2.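

Both branched groups on this aromatic nitrogen now give lower numbers than 4-fluorobenzyl, and an aromatic ring can be kept on such a group (a 3.9-fold lower number from compound 2 to compound 3 (0.59 log units; beyond the scatter)). The ring-bearing 1-phenylhexyl does not match the smaller 1-methylbutyl, however (a 3.2-fold higher number from compound 1 to compound 3 (0.51 log units; beyond the scatter)). No measurement available here accounts for either step.

Which part of 1-phenylhexyl, the ring, the branch or the chain, goes with these steps stays open. A 1-phenylethyl group or an unbranched hexyl chain on this nitrogen would help separate them in this assay as a further comparison.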